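This account rests on a few compounds, and the source may have more. Where it says the series, first, only, none or still open, it means among the compounds named here.

In a functional assay on Bel7402/5-FU cells (Homo sapiens) for antiproliferative activity, read by MTT assay, with a stated time of 72 h (a lower number here means a stronger inhibitor, a higher number a weaker inhibitor), compound 1 `C=C1C(=O)O[C@H]2[C@H]1CC/C(Cn1cc(Cn3cc(F)c(=O)n(Cc4ccccc4)c3=O)nn1)=C\CC[C@@]1(C)O[C@@H]21` gives 8840 nM, compound 2 `C=C1C(=O)O[C@H]2[C@H]1CC/C(COC(=O)Cn1cc(F)c(=O)n(Cc3ccc(Cl)cc3)c1=O)=C\CC[C@@]1(C)O[C@@H]21` gives 2420 nM and compound 3 `C=C1C(=O)O[C@H]2[C@H]1CC/C(COC(=O)Cn1cc(F)c(=O)n(Cc3cccc(F)c3)c1=O)=C\CC[C@@]1(C)O[C@@H]21` gives 3700 nM. Compound 3 thus lies within the scatter of compound 2, and its number is clearly lower than that of compound 1. Compound 4 `C=C1C(=O)O[C@H]2[C@H]1CC/C(COC(=O)Cn1cc(F)c(=O)n(CCC)c1=O)=C\CC[C@@]1(C)O[C@@H]21` differs from it by ethyl in place of 3-fluorophenyl on a saturated chain carbon bound to an aromatic nitrogen. Among the compounds with values here, the one measured step at this place, a 1.5-fold higher number from compound 2 to compound 3 (0.18 log units; within the scatter), stays within the scatter, but it keeps a ring, and no measured compound lacks one there. The expected step is therefore only a small rise, a 1.4-fold higher number from compound 3 to compound 4 (0.13 log units; within the scatter), with wide uncertainty. For compound 4 the estimate is 5000 nM, with an expected range from 2000 nM to 12000 nM.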

Compound 4, half-maximal inhibitory concentration: 9110 nM
Compound 4: the middle estimate sits 1.8-fold (0.26 log units) below what was measured; the range from low to high includes it.
By their numbers in this assay, from the lowest: compounds 2 and 3 (each within the scatter of the next); then compounds 1 and 4 (each within the scatter of the next).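

In this assay, the earlier step between two aromatic groups at this place, a 1.5-fold higher number from compound 2 to compound 3 (0.18 log units; within the scatter), gave no sign that the group there mattered. Losing the aromatic ring does register: ethyl in place of 3-fluorophenyl gives a 2.5-fold higher number from compound 3 to compound 4 (0.39 log units; beyond the scatter), and ethyl in place of 4-chlorophenyl gives a 3.8-fold higher number from compound 2 to compound 4 (0.58 log units; beyond the scatter). No measurement at hand accounts for this difference. From the compounds shown here alone, it remains open whether the aromatic ring itself or simply the size of the group counts here. A longer chain such as hexyl, or a saturated ring such as cyclohexylmethyl, could separate the two.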